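Swapping 3-methylphenyl for 4-chlorophenyl in compound 3

The compounds below may be only part of what the source reports. "The series", "measured", "known", "first", "only" and "open" are said of these compounds alone.

Among the measured compounds shown here, compound 2 `Cc1cccc(Cc2cnc(CCc3ccc(-c4ccccc4C(=O)O)cc3)[nH]2)c1` has the higher of the two numbers measured in an in vitro functional assay on cells for agonist activity at Bombesin receptor subtype-3 (Homo sapiens), read by luminescence and calcium flux (on this read-out lower numbers stand for an effect already at smaller amounts and higher numbers for an effect only at larger amounts of compound), giving 4310 nM; compound 1 `O=C(O)c1ccccc1-c1ccc(CCc2ncc(CC3CCCC3)[nH]2)cc1` gives 133 nM, and the only known step, a 32-fold higher number from compound 1 to compound 2 (1.51 log units; beyond the scatter), is large. Compound 3 `O=C(O)c1ccccc1-c1ccc(CCc2ncc(Cc3ccc(Cl)cc3)[nH]2)cc1` differs from compound 2 by 4-chlorophenyl in place of 3-methylphenyl on a saturated chain carbon bound to an aromatic carbon. For the measured compounds named here, no measured step exchanges one aromatic ring for another at this place, so the single cyclopentyl-to-aryl step offers little guidance for this change. A step of modest size in either direction, or none beyond the scatter, is expected. Compound 3 is therefore estimated at 3000 nM, with a range of 800 nM to 12000 nM, meaning a step of a 1.4-fold lower number from compound 2 to compound 3 (0.16 log units; within the scatter).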

Compound 3, half-maximal effective concentration: 2290 nM
Beside the measured number, compound 3's estimate is 1.3-fold (0.12 log units) above it; low and high end bracket the measured number.
By their numbers in this assay, from the lowest: compound 1; then compounds 3 and 2 (each within the scatter of the next).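

In this assay, the exchange of one aromatic ring for another gives a 1.9-fold lower number from compound 2 to compound 3 (0.27 log units; within the scatter) and so leaves 3-methylphenyl and 4-chlorophenyl at this place indistinguishable. The second aryl group also stands far from the cyclopentyl group, with a 17-fold higher number from compound 1 to compound 3 (1.24 log units; beyond the scatter) and thus the same direction as the earlier step from cyclopentyl to 3-methylphenyl. No measurement at hand gives a reason for this difference between the cyclopentyl and aryl groups. Still open, on these data alone, is whether a cyclohexyl ring or an open isobutyl chain would match cyclopentyl. Also open, as far as these compounds go, is how an amine on the aromatic ring would read.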